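A few compounds are considered here, and "the series" means these few. Any claim that something is new, unique, unknown or untested is made for them only; others in the source may bear on it.

In an ADME assay on CCRF-CEM cells (Homo sapiens) for cytotoxicity, with a stated time of 72 h (a lower number here means a stronger inhibitor, a higher number a weaker inhibitor), compound 1 `Clc1ccc(Cc2nn3cc(-c4ccc(Cl)cc4Cl)nc3s2)cc1` gives > 250000 nM, which is a limit of the measurement rather than a number, as described by the limit of > 250000 nM in this assay, at which 1 of the 3 values shown sits. Compound 2 `O=Cc1c(-c2ccc(F)cc2)nc2sc(Cc3ccc(Cl)cc3)nn12` gives 17000 nM in this assay. Compound 3 `O=Cc1c(-c2ccc(Br)cc2)nc2sc(Cc3ccc(Cl)cc3)nn12` gives 4000 nM in this assay, the lowest of the two numbers shown, separated from its neighbour by the step of a 4.3-fold lower number from compound 2 to compound 3 (0.63 log units; beyond the scatter). Compound 4 `O=Cc1c(-c2ccc(Cl)cc2Cl)nc2sc(Cc3ccc(Cl)cc3)nn12` differs from it by 2,4-dichlorophenyl in place of 4-bromophenyl on an aromatic carbon. Within the data shown here, only that one step, a modest one along the halogen series on the same ring, bears on this change, and no measured pair covers the second chlorine. Compound 4 is therefore expected to show a step of a 1.3-fold higher number from compound 3 to compound 4 (0.10 log units; within the scatter) in this assay. Compound 4 is estimated at 5000 nM, within a range from 1500 nM to 20000 nM.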

Compound 4, half-maximal inhibitory concentration: 79000 nM
Compound 4: middle estimate off by 16-fold (1.20 log units), on the low side; measured number outside the range, above it.
By their numbers in this assay, from the lowest: compound 3; then compound 2; then compound 4. At a limit, above all of these: compound 1.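

In this assay, this aromatic carbon tolerates less change than the halogen swap suggested: 2,4-dichlorophenyl gives a 20-fold higher number from compound 3 to compound 4 (1.30 log units; beyond the scatter) and a 4.6-fold higher number from compound 2 to compound 4 (0.67 log units; beyond the scatter). Among these compounds, with 2,4-dichlorophenyl held in place, formyl in place of hydrogen gives an at least 3.1-fold lower number from compound 1 to compound 4 (0.50 log units; beyond the scatter), the first reading of that group on this aryl background. The value of compound 1 is a limit and not a number: the limit of > 250000 nM in this assay, at which 1 of the 4 values shown sits.

The compounds shown leave open whether the second chlorine or the change of halogen carries the large step. They also leave open how an amine or a carboxylic acid would read in place of the formyl group.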